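This account rests on a few compounds, and the source may have more. Where it says the series, first, only, none or still open, it means among the compounds named here.

In a functional assay on A549 cells (Homo sapiens) for cytotoxicity, read by MTT assay, with a stated time of 72 h (a higher number here means a weaker inhibitor, a lower number a stronger inhibitor), compound 1 (`CSCC[C@H](NC1=CC(=O)C=C(C[C@]2(C)[C@@H](C)CC[C@]3(C)C(C)=CCC[C@@H]23)C1=O)C(=O)O`) gives 47300 nM and compound 2 (`CC1=CCC[C@H]2[C@](C)(CC3=CC(=O)C=C(N[C@@H](C(=O)O)C(C)C)C3=O)[C@@H](C)CC[C@]12C`) gives 23800 nM. Among the measured compounds shown here, these are the only two measurements so far. They lie within the scatter of each other, so compound 2 cannot be separated from compound 1 on these numbers, and both remain in the same range.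

The next compound is compound 3 (`CC1=CCC[C@H]2[C@](C)(CC3=CC(=O)C=C(N[C@@H](C)C(=O)O)C3=O)[C@@H](C)CC[C@]12C`), and the change is 1-carboxyethyl in place of 1-carboxy-2-methylpropyl on an amine nitrogen. In words, 1-carboxyethyl takes the place of 1-carboxy-2-methylpropyl on an amine nitrogen, with the shared core untouched.

For the measured compounds named here, one measured step bears on this, at the same amine nitrogen: a 2.0-fold lower number from compound 1 to compound 2 (0.30 log units; within the scatter). Going by the values given here, that is a single step and a different exchange of groups, and no measurement yet covers 1-carboxyethyl itself, so the basis is thin. Going by that one step, no change beyond the scatter is expected in this assay, and no firm direction can be assigned.

For compound 3 the expected value is 30000 nM, with an estimated range of 14000 nM to 65000 nM. This estimate corresponds to an expected 1.3-fold higher number from compound 2 to compound 3 (0.10 log units; within the scatter).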

Compound 3, half-maximal inhibitory concentration: 54300 nM
For compound 3 the middle estimate is 1.8-fold (0.26 log units) below the measured one, within the range that was stated.
By their numbers in this assay, from the lowest: compounds 2, 1 and 3 (each within the scatter of the next, the first and the last beyond it).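

In this assay, among the compounds shown here, 1-carboxyethyl in place of 1-carboxy-2-methylpropyl on the amine nitrogen gives a 2.3-fold higher number from compound 2 to compound 3 (0.36 log units; beyond the scatter), the first step at this position to clear the scatter, though only modestly. The other new step, a 1.1-fold higher number from compound 1 to compound 3 (0.06 log units; within the scatter), for hydrogen in place of (methylsulfanyl)methyl on the saturated chain carbon, stays within the scatter, so compound 1 cannot be separated from either of the other two, and it goes against any reading that the loss of chain atoms alone raises the number. Nothing available accounts for the difference between these groups on the amine nitrogen.

Still open, going by these compounds, is whether a phenyl ring, a hydroxyl or an amine on this side chain would move the number outside the narrow band spanned by these three compounds. Also open, on these data alone, is what the carboxylic acid contributes, which a methyl ester or a primary amide in its place would test, and what the opposite configuration at the defined stereocentre of the side chain would give.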